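A few compounds are considered here, and "the series" means these few. Any claim that something is new, unique, unknown or untested is made for them only; others in the source may bear on it.

Three compounds share one core and differ only in the substituent on one aromatic ring. Compound 1 `COc1ccc(-c2nc(CNc3ccc(C(=O)NO)cc3)n(-c3ccccc3)n2)cc1` gives 163 nM in an assay on Sf9 cells for inhibition of protein deacetylase HDAC6 (Homo sapiens), read by fluorescence, with a stated time of 40 min; a lower number here means a stronger inhibitor, a higher number a weaker inhibitor. Compound 2 `O=C(NO)c1ccc(NCc2nc(-c3cccc(Cl)c3)nn2-c2ccccc2)cc1` gives 115 nM. Compound 3 `O=C(NO)c1ccc(NCc2nc(-c3ccc(Cl)cc3)nn2-c2ccccc2)cc1` gives 181 nM; the steps of a 1.1-fold higher number from compound 1 to compound 3 (0.05 log units; within the scatter) and a 1.6-fold higher number from compound 2 to compound 3 (0.20 log units; within the scatter) both sit within the scatter, so nothing separates these three.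

Compound 4 `O=C(NO)c1ccc(NCc2nc(-c3ccc(F)cc3)nn2-c2ccccc2)cc1` carries the change (fluoro in place of chloro on an aromatic carbon). The closest comparisons are swaps on the same ring: a 1.1-fold higher number from compound 1 to compound 3 (0.05 log units; within the scatter) and a 1.6-fold higher number from compound 2 to compound 3 (0.20 log units; within the scatter), neither beyond the scatter. A further small swap of a halogen is therefore expected to give no step beyond the scatter, a 1.1-fold higher number from compound 3 to compound 4 (0.04 log units; within the scatter). The estimate for compound 4 is 200 nM, with a range from 100 nM to 420 nM.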

Compound 4, half-maximal inhibitory concentration: 115 nM
The estimate for compound 4 lay 1.7-fold (0.24 log units) above the measured number, and the stated range covers the measured number.
By their numbers in this assay, from the lowest: compounds 2, 4, 1 and 3 (each within the scatter of the next).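

Fluoro in place of chloro at this position gives a 1.6-fold lower number from compound 3 to compound 4 (0.20 log units; within the scatter) in this assay, so a second halogen on this carbon also leaves the number within the scatter. The comparisons with the other two compounds agree, with no change at the digits printed from compound 2 to compound 4 (within the scatter) and a 1.4-fold lower number from compound 1 to compound 4 (0.15 log units; within the scatter). Nothing measured here offers an explanation for how little these swaps change the number. Still open, from the compounds shown here alone, is whether an amine or a carboxylic acid on this ring, groups quite unlike chloro, fluoro and methoxy, would give a step beyond the scatter.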